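A few compounds are considered here, and "the series" means these few. Any claim that something is new, unique, unknown or untested is made for them only; others in the source may bear on it.

Among the compounds with values here, in a functional assay on HT cells (Homo sapiens) for antiproliferative activity, read by fluorescence, with a stated time of 72 h (on this read-out lower numbers stand for stronger inhibition of growth and higher numbers for weaker inhibition of growth), compound 2 `CC(C)c1n[nH]c2c(NCc3ccc(-c4ccccn4)cc3)nc(S)nc12` gives 2760 nM, the higher of the two numbers measured so far, while compound 1 `CC(C)c1n[nH]c2c(NCc3ccc(-c4ccccn4)cc3)nc(SC(C)C(C)O)nc12` gives 190 nM. Compound 3 `CC(C)c1n[nH]c2c(NCc3ccc(-c4ccccn4)cc3)nc(SC3CCCCC3N)nc12` changes compound 2 in one place: 2-aminocyclohexyl in place of hydrogen on a sulfur. Within the data shown here, only one measured step bears on this, the large 15-fold higher number from compound 1 to compound 2 (1.16 log units; beyond the scatter), where hydrogen replaced 2-hydroxy-1-methylpropyl on a sulfur. Putting a group back on that sulfur should therefore lower the number by a similarly large amount, although the group here is different. The expected change is an estimated 18-fold lower number from compound 2 to compound 3 (1.26 log units; beyond the scatter). The estimate for compound 3 is 150 nM, with an expected range of 30 nM to 700 nM.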

Compound 3, concentration for 50% growth inhibition: 139 nM
Compound 3: the middle estimate sits 1.1-fold (0.03 log units) above what was measured; measured number inside the range.
By their numbers in this assay, from the lowest: compounds 3 and 1 (each within the scatter of the next); then compound 2.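

In this assay the sulfur accepts a second, quite different group: a 20-fold lower number from compound 2 to compound 3 (1.30 log units; beyond the scatter) shows that the gain from filling this position is not tied to 2-hydroxy-1-methylpropyl. A ring bearing an amine and an open chain bearing a hydroxyl give results within the scatter of each other, as a 1.4-fold lower number from compound 1 to compound 3 (0.14 log units; within the scatter) shows. Nothing available here explains this effect of substitution on the sulfur.

Still open, as far as these compounds go, is whether the amine contributes at all, which plain cyclohexyl would test. A small methyl group or a carboxylic acid on the sulfur would show how far this tolerance extends.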